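The compounds below may be only part of what the source reports. "The series", "measured", "known", "first", "only" and "open" are said of these compounds alone.

The measured compounds:
compound 1 `CC(C)N(Cc1cccc(OCCCCCC(=O)O)c1)C(=O)c1ccccc1`, > 26000 nM;
compound 2 `CCOC(=O)CCCCCOc1cccc(CN(C(=O)c2ccccc2)C(C)C)c1`, > 26000 nM.

In an ADME assay on HEK293 cells (Homo sapiens) for cytotoxicity, read by CellTiter-Glo and resazurin assay, with a stated time of 72 h (a lower number here means that less compound is needed, a higher number that more compound is needed for the effect), compound 1 reaches only the limit of the assay, > 26000 nM. Compound 2 likewise gives only a limit in this assay, > 26000 nM. The step that the two limits leave unreadable from compound 1 to compound 2 therefore cannot be read, because of the limit of > 26000 nM in this assay, at which 2 of the 2 values shown sit. Compound 3 `CCOC(=O)CCCCCOc1cccc(CN(C(=O)c2ccc(-c3cccc4ccccc34)cc2)C(C)C)c1` differs from compound 2 by naphthalen-1-yl in place of hydrogen on an aromatic carbon. Among the measured compounds shown here, the single measured step, from compound 1 to compound 2, is unreadable in size and concerns another part of the molecule, so nothing measured here bears on the change leading to compound 3. From what is shown, no direction beyond the scatter can be expected. Compound 3 is expected to give about 25000 nM in this assay, within a range of 8000 nM to 80000 nM, quite possibly again only as a limit. The resulting step, an at least 1.0-fold lower number from compound 2 to compound 3 (0.01 log units; that floor lies within the scatter), is what is expected.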

Compound 3, half-maximal effective concentration: > 26000 nM
Compound 3 was reported as a limit (the forecaster's own chance of this, stated with the estimate: 55%); at least 1.0-fold (0.01 log units) between middle value and limit.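

Compound 3, like compound 2, is reported in this assay only as a limit, so no size can be read for the step between them: the limit of > 26000 nM in this assay, at which 3 of the 3 values shown sit. The compounds shown leave open whether naphthalen-1-yl in place of hydrogen changes the number in this assay at all.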